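Saturated ring in place of benzyl on the side chain

The source may hold more compounds than are shown below. What is called first, only, known or untested is meant among the compounds shown, and "the series" means these compounds.

Three compounds of the series have numbers in an assay for binding affinity to Alpha-1A adrenergic receptor (Homo sapiens); a lower number here means a stronger inhibitor, a higher number a weaker inhibitor. Compound 1 `CN1CCC[C@@H]1Cn1nc(CCc2ccccc2)c2ccccc2c1=O` gives 200 nM in this assay. Compound 2 `O=c1c2ccccc2c(Cc2ccc(Cl)cc2)nn1CCNCCCCc1ccc(OCCCN2CCCCCC2)cc1` gives 316 nM, a number that lies within the scatter of that of compound 1, so the two are not told apart. Within the data shown here, compound 3 `CN1CCC(n2nc(Cc3ccc(Cl)cc3)c3ccccc3c2=O)CC1` gives 15.9 nM, well below compound 1, beyond the scatter; compound 3 differs from compound 1 at more than one place, so no single step is drawn between them. Compound 1 therefore sits with compound 2 in the weaker part of the three numbers, with compound 3 the only one clearly stronger.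

Compound 4 `CN1CCC[C@@H]1Cn1nc(CC2CCCCC2)c2ccccc2c1=O` has not yet been measured in this assay. It differs from compound 1 in one place: cyclohexyl in place of benzyl on a saturated chain carbon bound to an aromatic carbon. Among the measured compounds shown here, no measured pair carries this change, so nothing here shows how this assay responds to it. The step from compound 1 to compound 4 is expected to be small, likely no further than the scatter in either direction, with a slight lean toward a higher number, a 1.4-fold higher number from compound 1 to compound 4 (0.15 log units; within the scatter). Compound 4 is thus estimated at 280 nM in this assay, within a range from 90 nM to 900 nM.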

Compound 4, inhibition constant: > 1990 nM
Compound 4: no number, only a limit (the forecaster's own chance of this, stated with the estimate: 3%); middle value at least 7.1-fold (0.85 log units) away from the limit.
By their numbers in this assay, from the lowest: compound 3; then compounds 1 and 2 (each within the scatter of the next). At a limit, above all of these: compound 4.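

This is the only step shown between compounds that differ in one place, and it shows that this assay responds strongly at this position: cyclohexyl in place of benzyl on a saturated chain carbon bound to an aromatic carbon gives an at least 9.9-fold higher number from compound 1 to compound 4 (0.99 log units; beyond the scatter). The side chain of compound 1 therefore does not tolerate every six-membered ring of carbon here, even though the change leaves hydrogen-bond donors, hydrogen-bond acceptors and net charge unchanged in the counts for the two groups. The step has only a lower bound, and its full size stays unknown, as compound 4 gives a limit rather than a number: the limit of > 1990 nM in this assay, at which 1 of the 4 values shown sits.

This single pair cannot separate the loss of the aromatic ring from any other difference between benzyl and cyclohexyl, nor show whether the same change would act alike on another member of the series. Also open, going by these compounds, is how this place responds to a pyridyl ring, a longer chain ending in phenyl, or an amine or carboxylic acid on the terminal ring.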